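A few compounds are considered here, and "the series" means these few. Any claim that something is new, unique, unknown or untested is made for them only; others in the source may bear on it.

Two analogues sharing one core have been measured in an assay on Sf9 cells for inhibition of protein deacetylase HDAC6 (Homo sapiens), read by fluorescence, with a stated time of 40 min, tested at 100 nM; on this read-out higher numbers stand for more inhibition at the one concentration tested (going by the name of the read-out) and lower numbers for less inhibition. Compound 1, `COc1ccc(-c2nc(CNc3ccc(C(=O)NO)cc3)n(-c3ccccc3)n2)cc1`, gives 77.6% in this assay. Compound 2, `CCc1ccc(-n2nc(-c3ccccc3)nc2CNc2ccc(C(=O)NO)cc2)cc1`, gives 38.3% in this assay, which is the lowest of the two numbers and stands a step below compound 1 that lies beyond the usual scatter. Compound 3, `Cc1ccc(-n2nc(-c3ccccc3)nc2CNc2ccc(C(=O)NO)cc2)cc1`, has not yet been measured in this assay. It differs from compound 2 only at the 4-ethylphenyl group: hydrogen in place of methyl on a saturated chain carbon bound to an aromatic carbon, so that 4-ethylphenyl becomes 4-methylphenyl. Among the measured compounds shown here, no measured pair shows the effect of such a change here. A shift of one carbon on a saturated chain at this place is expected to move the number little, with the step from compound 2 to compound 3 in this assay, a number 1.7 percentage points higher from compound 2 to compound 3 (within the scatter), expected to stay within the scatter in either direction. Compound 3 is therefore estimated at 40% in this assay, with a range from 22% to 58%.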

Compound 3, a percentage reported as inhibition, at one concentration (the size of the read-out at that concentration, not a potency): 60.7%
Estimate against measurement, compound 3: 20.7 percentage points below, and the stated range ends below it.
By their numbers in this assay, from the lowest: compound 2; then compound 3; then compound 1.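

In this assay the change from 4-ethylphenyl to 4-methylphenyl gives a number 22.4 percentage points higher from compound 2 to compound 3 (beyond the scatter) and so shows that this place is not indifferent to a single carbon: hydrogen in place of methyl on a saturated chain carbon bound to an aromatic carbon is enough to move the number beyond the scatter. Among the compounds shown here, this pair is the first to differ in one place, so it offers the first direct reading of any single change, though only in this one direction and at this one place. Nothing measured on these compounds speaks to what lies behind the step.

As far as these compounds go, whether a propyl chain, an amine or a carboxylic acid at this place would extend the step or reverse it remains open. Also open, from the compounds shown here alone, is whether a step of this size would hold at a different concentration.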